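An ester in place of the amide of compound 1

This account rests on a few compounds, and the source may have more. Where it says the series, first, only, none or still open, it means among the compounds named here.

Measured so far in an assay on cells for agonist activity at vitamin D3 receptor (Homo sapiens), read by microscopy; a higher number here means that more compound is needed for the effect, a lower number that less compound is needed:
Compound 1 `CCn1c(C(=O)NCCC(=O)OC)ccc1C(CC)(CC)c1ccc(C#CC(O)(CC)CC)c(C)c1` gives > 50 nM, which is a limit of the assay.
Compound 2 `CCn1c(C(=O)NCc2ccc(OC)cc2)ccc1C(CC)(CC)c1ccc(C#CC(O)(CC)CC)c(C)c1` gives > 50 nM, also a limit of the assay.
Compound 3 `C#CCCOC(=O)c1ccc(C(CC)(CC)c2ccc(C#CC(O)(CC)CC)c(C)c2)n1CC` gives > 50 nM, again a limit of the assay.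

Compound 1 thus has no number of its own in this assay, only a limit, and the two other compounds stand at the same limit. The new compound 4 `CCn1c(C(=O)On2nnc3ccccc32)ccc1C(CC)(CC)c1ccc(C#CC(O)(CC)CC)c(C)c1` differs from compound 1 in one place: a group of 10 heavy atoms (6 carbon, 3 nitrogen, 1 oxygen; one five-membered aromatic ring with 3 hetero atoms, one six-membered aromatic ring of carbon only) in place of a group of 7 heavy atoms (4 carbon, 1 nitrogen, 2 oxygen; no ring), on a carbonyl carbon.

Two measured steps start from compound 1 and change the same carbonyl carbon: a step that the two limits leave unreadable from compound 1 to compound 2 and a step that the two limits leave unreadable from compound 1 to compound 3. The step that the two limits leave unreadable from compound 2 to compound 3 is unreadable as well. None of these steps has a readable size because of the limit of > 50 nM in this assay, at which 3 of the 3 values shown sit. No direction or size of the step to compound 4 can therefore be taken from the data in this assay.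

Compound 4 is expected to give about 100 nM, within 30 nM to 500 nM. The expected step that the limit leaves unreadable from compound 1 to compound 4 most likely stays unreadable, with compound 4 again at the limit.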

Compound 4, half-maximal effective concentration: > 50 nM
Compound 4: a limit, no number (the forecaster's own chance of this, stated with the estimate: 80%); the middle value does not contradict the limit.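

The steps from compound 1, compound 2 and compound 3 to compound 4 cannot be read, because all four compounds stand at a limit and none has a number of its own: the limit of > 50 nM in this assay, at which 4 of the 4 values shown sit.
The compounds shown leave open whether changing the group on the carbonyl carbon alters the concentration needed at all, and in which direction.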